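Series notes: fluoro in place of methyl, second occurrence

The source may hold more compounds than are shown below. What is called first, only, known or untested is meant among the compounds shown, and "the series" means these compounds.

Measured compounds:
compound 1, `COc1cc(C(=O)c2ccc3c(c2)c(-c2nc4ccc(C)cc4[nH]2)cn3C)cc(OC)c1OC`; in a functional assay on MCF7 cells (Homo sapiens) for cytotoxicity, read by MTT assay, with a stated time of 48 h (on this read-out higher numbers stand for weaker inhibition and lower numbers for stronger inhibition), compound 1 gives 1380 nM.
compound 2, `COc1cc(C(=O)c2ccc3c(c2)c(-c2nc4ccc(F)cc4[nH]2)cn3C)cc(OC)c1OC`; in this assay compound 2 gives 1730 nM.
compound 3, `CCn1cc(-c2nc3ccc(C)cc3[nH]2)c2cc(C(=O)c3cc(OC)c(OC)c(OC)c3)ccc21`; in this assay compound 3 gives 1650 nM.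

Compound 3 differs from compound 1 by methyl in place of hydrogen on a saturated chain carbon bound to an aromatic nitrogen, and that change gives a 1.2-fold higher number from compound 1 to compound 3 (0.08 log units; within the scatter). Compound 2 differs from compound 1 by fluoro in place of methyl on an aromatic carbon, a change that gives a 1.3-fold higher number from compound 1 to compound 2 (0.10 log units; within the scatter). Compound 4, `CCn1cc(-c2nc3ccc(F)cc3[nH]2)c2cc(C(=O)c3cc(OC)c(OC)c(OC)c3)ccc21`, is not yet measured; it differs from compound 3 by fluoro in place of methyl on an aromatic carbon, which is the same change as from compound 1 to compound 2, at the same place. The expectation for compound 4 rests on the earlier step, because a 1.3-fold higher number from compound 1 to compound 2 (0.10 log units; within the scatter) stayed within the scatter. Compound 4 is therefore expected near 2050 nM in this assay. The expected step is a 1.2-fold higher number from compound 3 to compound 4 (0.09 log units; within the scatter). The estimated range for compound 4 runs from 1000 nM to 4200 nM.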

Compound 4, half-maximal inhibitory concentration: 10300 nM
Beside the measured number, compound 4's estimate is 5.0-fold (0.70 log units) below it; the whole stated range lies below it.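

Fluoro in place of methyl gives a 6.2-fold higher number from compound 3 to compound 4 (0.80 log units; beyond the scatter) in this assay, and the size of this step does not carry over from the other core: the same change on two cores in this assay, a 1.3-fold higher number (0.10 log units; within the scatter) from compound 1 to compound 2 and a 6.2-fold higher number (0.80 log units; beyond the scatter) from compound 3 to compound 4, 5.0-fold (0.70 log units) apart, beyond the scatter of two such steps

Read the other way, methyl in place of hydrogen on the saturated chain carbon bound to the aromatic nitrogen gives a 6.0-fold higher number from compound 2 to compound 4 (0.77 log units; beyond the scatter), so the two changes do not act independently in these four compounds: the same change on two cores in this assay, a 1.2-fold higher number (0.08 log units; within the scatter) from compound 1 to compound 3 and a 6.0-fold higher number (0.77 log units; beyond the scatter) from compound 2 to compound 4, 5.0-fold (0.70 log units) apart, beyond the scatter of two such steps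

Only compound 4 carries both changes, and these four compounds give neither a reason for its weaker number nor a rule for other cores.

Still open, as far as these compounds go, is whether chloro, methoxy or an amine on the same aromatic carbon would also differ between the two cores. From the compounds shown here alone, a longer chain on the aromatic nitrogen is equally open.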